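This account rests on a few compounds, and the source may have more. Where it says the series, first, only, none or still open, it means among the compounds named here.

Measured in a physicochemical assay for lipophilicity, at pH 7.4; on this read-out higher numbers stand for higher lipophilicity and lower numbers for lower lipophilicity:
- compound 1 `C[C@@H]1[C@@H]2CN(c3nc(Nc4cnn(CCO)c4)ncc3F)C[C@]12NC(=O)[C@@H]1C[C@H]1C#N`: 1.71
- compound 2 `CCNC(=O)c1ccc(Nc2nccc(N3CC4CC(C3)N4C(=O)C3CC3)n2)cc1`: 1.7
- compound 3 `C[C@@H]1[C@@H]2CN(c3nc(Nc4cnn(C)c4)ncc3F)C[C@]12NC(=O)[C@@H]1C[C@H]1C#N`: 2.35

Among these three, compound 1 cannot be told apart from compound 2 within the scatter, and it lies clearly under compound 3. Compound 4 `C[C@@H]1[C@@H]2CN(c3nc(Nc4cnn(CCO)c4)ncc3F)C[C@]12NC(=O)[C@H]1C[C@@H]1C#N` is the next to be measured. The change is the two compounds have the same atoms and bonds and differ only in configuration as drawn: 2 of 5 stereo elements differ; a stereocentre at a saturated ring carbon is drawn R in compound 1 and S in compound 4; a stereocentre at a saturated ring carbon is drawn R in compound 1 and S in compound 4: the atoms and bonds stay the same, and two stereocentres at saturated ring carbons are drawn R in compound 1 and S in compound 4. Among the compounds with values here, the only measured step, a number 0.64 log units higher from compound 1 to compound 3 (beyond the scatter), swaps hydroxymethyl for hydrogen and leaves configuration untouched, so it offers no direct guide. Within the data shown here, no measured step changes configuration alone. What is expected is a number 0.01 log units lower from compound 1 to compound 4 (within the scatter), with no shift beyond the scatter in either direction. For compound 4 the estimated value is 1.7, with an expected range from 1.35 to 2.05.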

Compound 4, distribution coefficient: 1.75
Compound 4: middle estimate off by 0.05 log units, on the low side, and the stated range covers the measured number.
By their numbers in this assay, from the lowest: compounds 2, 1 and 4 (each within the scatter of the next); then compound 3.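

In this assay, turning the two saturated ring carbons from R to S gives a number 0.04 log units higher from compound 1 to compound 4 (within the scatter), so this reversal of configuration leaves the read-out unchanged within the scatter. The earlier step, a number 0.64 log units higher from compound 1 to compound 3 (beyond the scatter), involved a change of group, not of configuration. The new pair tests configuration alone because nothing else separates its members: the fact that compounds 1 and 4 differ only in the configuration as drawn.

Going by these compounds, whether the same reversal would also leave compound 3 unchanged remains open. So does the effect of an amine or a carboxylic acid in place of the hydroxymethyl.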